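The compounds below may be only part of what the source reports. "The series", "measured", "known", "first", "only" and "open" are said of these compounds alone.

Compound 1 `CCCCCCOP(=O)(O)OCCSC(=S)N1CCCCCC1`: 17200 nM
Compound 2 `CCCCCCOP(=O)(O)OCCSC(=S)N1CCN(C)CC1`: 73000 nM
Compound 3 `CCCCCCOP(=O)(O)OCCSC(=S)N1CCCC1`: 54000 nM

All three were measured in a functional assay on MDA-MB-231 cells (Homo sapiens) for inhibition, read by MTT assay, with stated times of 18 h and 4 h; a higher number here means a weaker inhibitor, a lower number a stronger inhibitor. Compound 3 gives the second highest of these three numbers: the gap a 1.4-fold lower number from compound 2 to compound 3 (0.13 log units; within the scatter) is within the scatter, while a 3.1-fold higher number from compound 1 to compound 3 (0.50 log units; beyond the scatter) lies beyond it. Compound 4 `CCCCCCCCCCCCCCCCOP(=O)(O)OCCSC(=S)N1CCCC1` differs from compound 3 by decyl in place of hydrogen on a saturated chain carbon, six bonds along the chain from an oxygen on an unsaturated carbon. Among the measured compounds shown here, none of the measured steps bears on this change; the three known steps, such as a 4.2-fold higher number from compound 1 to compound 2 (0.63 log units; beyond the scatter), alter only the group on the thiocarbonyl carbon, and the chain was never varied, so they give no guide to size or direction here. Compound 4 is nevertheless expected to give a lower number, estimated at 12000 nM with a range from 2500 nM to 60000 nM. That expectation amounts to a 4.5-fold lower number from compound 3 to compound 4 (0.65 log units; beyond the scatter), and it is an estimate rather than a measurement.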

Compound 4, half-maximal inhibitory concentration: 69000 nM
Compound 4: the middle estimate sits 5.8-fold (0.76 log units) below what was measured; measured number above the stated range.
By their numbers in this assay, from the lowest: compound 1; then compounds 3, 4 and 2 (each within the scatter of the next).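

Among the compounds shown here, compound 4 is the first change to the chain rather than to the group on the thiocarbonyl carbon, and in this assay the decyl addition gives a 1.3-fold higher number from compound 3 to compound 4 (0.11 log units; within the scatter). With pyrrolidin-1-yl held constant, the two compounds therefore cannot be told apart in this assay, despite the added decyl. Nothing available explains this result.

On these data alone, it remains open whether decyl would behave the same way alongside the azepan-1-yl group of compound 1. As far as these compounds go, the effect of a chain ending in an amine or a carboxylic acid also remains open.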